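The compounds below may be only part of what the source reports. "The series", "measured", "known", "first", "only" and "open" are said of these compounds alone.

Compound 2 `C#CCNC(=O)[C@H](CC(C)C)NC(=O)N1CCOCC1` gives 97000 nM in an assay for inhibition of cathepsin S (Homo sapiens) (on this read-out lower numbers stand for stronger inhibition and higher numbers for weaker inhibition), the highest number of the two measured; compound 1 `CC(C)C[C@H](NC(=O)N1CCOCC1)C(=O)N[C@H](C#N)CCc1ccccc1` gives 47 nM, a gap that lies beyond the usual scatter. Compound 3 `CC(C)C[C@H](NC(=O)N1CCOCC1)C(=O)N[C@@H](C)C#N` is not yet measured. It differs from compound 2 in one place: 1-cyanoethyl in place of propargyl on an amide-type nitrogen. Among the measured compounds shown here, no measured pair shows this exact change, so its size is not known from the data. Compound 3 does, however, now carry the nitrile-bearing carbon on the amide nitrogen that compound 1 also carries, with the defined stereocentre, whereas compound 2 has no nitrile there. Given that compound 1 gives 47 nM and compound 2 gives 97000 nM, a large step towards lower numbers is expected from compound 2 to compound 3, a 65-fold lower number from compound 2 to compound 3 (1.81 log units; beyond the scatter), though not all the way to the number of compound 1. Compound 3 is estimated at 1500 nM, in the range 200 nM to 10000 nM.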

Compound 3, half-maximal inhibitory concentration: 142 nM
For compound 3 the middle estimate is 11-fold (1.02 log units) above the measured one; the measured number lies below the stated range.
By their numbers in this assay, from the lowest: compound 1; then compound 3; then compound 2.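

In this assay, 1-cyanoethyl in place of propargyl on an amide-type nitrogen is by itself a large step of a 680-fold lower number from compound 2 to compound 3 (2.83 log units; beyond the scatter), so the side chain of compound 1 is not needed to reach a low number on this scaffold. Hydrogen in place of benzyl on a saturated chain carbon, two bonds along the chain from an amide-type nitrogen and a triple-bonded carbon, is only a modest step beyond the scatter a 3.0-fold higher number from compound 1 to compound 3 (0.48 log units; beyond the scatter), so the benzyl contributes far less than the propargyl-to-1-cyanoethyl change. Nothing available explains either step.

The compounds shown leave open how the number responds to an ethyl or propyl chain on that carbon, and whether a carboxamide or an aldehyde in place of the nitrile holds it. Going by these compounds, the opposite configuration at the stereocentre also remains open.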